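From compound 3 to compound 4: a larger ring

This account rests on a few compounds, and the source may have more. Where it says the series, first, only, none or still open, it means among the compounds named here.

For the measured compounds named here, in a physicochemical assay for solubility, using the shake flask method, in phosphate buffer, measured as kinetic solubility, with a stated time of 20 h, at pH 6.5 (on this read-out lower numbers stand for lower solubility and higher numbers for higher solubility), compound 3 `FC1(F)CCC(c2nc3cnc(Nc4ccc(C(F)(F)F)cn4)cc3[nH]2)C1` gives 120000 nM, the only actual number among the values so far. Compound 1 `Fc1ccc(-c2nc3cnc(Nc4ccccn4)cc3[nH]2)cc1F` reports < 5000 nM, which in this assay is a limit and not a number. Compound 2 `Fc1ccnc(Nc2cc3[nH]c(-c4ccc(F)c(F)c4)nc3cn2)c1` reports < 5000 nM, which is also a limit. Going by the values given here, the one step between measured neighbours, a step that the two limits leave unreadable from compound 1 to compound 2, is a change of another kind and offers no size to carry over.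

Compound 4 `FC(F)(F)c1ccc(Nc2cc3[nH]c([C@H]4CC[C@H](C(F)(F)F)CC4)nc3cn2)nc1` keeps the rest of compound 3 and differs in one place: 4-(trifluoromethyl)cyclohexyl in place of 3,3-difluorocyclopentyl on an aromatic carbon. In short, 4-(trifluoromethyl)cyclohexyl stands in place of 3,3-difluorocyclopentyl on an aromatic carbon. Among the compounds with values here, no measured step covers this exchange, so its size can only be judged from where the values sit. The relevant evidence is the limit of < 5000 nM in this assay, at which 2 of the 3 values shown sit, shared by compound 1 and compound 2. On that thin ground a fall from compound 3 is expected rather than a rise, and a result reported only as that limit is a real possibility. The expected step is an 8.0-fold lower number from compound 3 to compound 4 (0.90 log units; beyond the scatter), a fall beyond the usual scatter. For compound 4 the estimate is 15000 nM, with an expected range of 3000 nM to 70000 nM.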

Compound 4, solubility: < 5000 nM
Compound 4 was reported as a limit; the forecaster's own chance of this, stated with the estimate: 35%; middle value at least 3.0-fold (0.47 log units) away from the limit.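

For the compounds shown here, with the rest of compound 3 kept, the group on this aromatic carbon, between two ring nitrogen atoms, is enough on its own to shift the read-out in this assay: exchanging 3,3-difluorocyclopentyl for 4-(trifluoromethyl)cyclohexyl gives an at least 24-fold lower number from compound 3 to compound 4 (1.38 log units; beyond the scatter), the first step with a readable size and one beyond the scatter. Compound 4 reports < 5000 nM, which is a limit. A change at this position, away from the fluoro exchange that the earlier compounds offered, therefore also ends at the value that dominates the set: the limit of < 5000 nM in this assay, at which 3 of the 4 values shown sit.

On these data alone, the exchange alters ring size, the fluorine pattern and the heavy-atom count together, so the data do not show which of these differences carries the step, and the actual value of compound 4 remains unknown. A plain cyclohexyl, or a cyclohexyl carrying an amine or a carboxylic acid on this same aromatic carbon, would separate ring size from the fluorinated substituent and test whether this position can return a number instead of a limit.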